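Acetylation of the primary hydroxyl in an iodinated nucleoside

The source may report more compounds than this note shows. Statements on the series, on what has been measured and on what is new or still open speak of the compounds shown alone.

Measured compounds:
compound 1 `O=c1cc(I)n([C@@H]2O[C@H](CO)[C@@H](O)[C@H]2O)c(=O)[nH]1`: > 50000 nM
compound 2 `O=Cc1cc(=O)[nH]c(=O)n1[C@@H]1O[C@H](CO)[C@@H](O)[C@H]1O`: > 50000 nM

In a functional assay on LOX cells (Homo sapiens) for antiproliferative activity, read by WST assay, with a stated time of 3 days (a lower number here means a stronger inhibitor, a higher number a weaker inhibitor), compound 1 reaches only the limit of the measurement, > 50000 nM. Compound 2 likewise gives only a limit in this assay, > 50000 nM. Among the compounds with values here, the single step between measured compounds, a step that the two limits leave unreadable from compound 1 to compound 2, therefore cannot be read in size or direction, since the limit of > 50000 nM in this assay, at which 2 of the 2 values shown sit, is where both values sit; nothing measured so far distinguishes formyl from iodo on the aromatic carbon.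

Compound 3 `CC(=O)OC[C@H]1O[C@@H](n2c(I)cc(=O)[nH]c2=O)[C@H](O)[C@@H]1O` differs from compound 1 by acetyl in place of hydrogen on an oxygen on a saturated carbon. Within the data shown here, no measured step touches the oxygen on the saturated carbon, so the only footing is the standing of compound 1 itself at the limit. The expectation is that compound 3 stays in the same region, with a step that the limit leaves unreadable from compound 1 to compound 3 from compound 1 that is not expected to move it past the scatter. Compound 3 is thus estimated at 60000 nM, within 15000 nM to 250000 nM, and most probably reported again only as a limit.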

Compound 3, half-maximal inhibitory concentration: 1100 nM
The estimate for compound 3 lay 55-fold (1.74 log units) above the measured number; the measured number lies below the stated range.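

In this assay, within the data shown here, acetyl in place of hydrogen on an oxygen on a saturated carbon gives an at least 45-fold lower number from compound 1 to compound 3 (1.65 log units; beyond the scatter), so hydroxymethyl to acetoxymethyl is the first change with a readable effect, and it is beyond the scatter. Compound 3 is the only one of the compounds shown with a measured number rather than a limit: the limit of > 50000 nM in this assay, at which 2 of the 3 values shown sit. Compound 1 remains a limit, > 50000 nM, so the step has a bound but no exact size, and it shows only that this hydroxy position responds strongly to change in this assay.

From the compounds shown here alone, whether this response is specific to acetyl stays open, as a longer chain such as butanoyl, or an amine or carboxylic acid at the same place, would show. Also open, going by these compounds, is whether the acetoxymethyl change depends on iodo, as formyl in its place on the compound 2 core would test.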